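The compounds below may be only part of what the source reports. "The series", "measured", "known", "first", "only" and "open" are said of these compounds alone.

Compound 1 `CC1(C)[C@H]2CC[C@]1(C)N(Cc1cn(-c3ccc(F)cc3)nn1)C(=O)C2`, compound 2 `CC1(C)[C@H]2CC[C@]1(C)N(Cc1cn(-c3ccccc3Cl)nn1)C(=O)C2` and compound 3 `CC1(C)[C@H]2CC[C@]1(C)N(Cc1cn(-c3ccccc3O)nn1)C(=O)C2` share one core and differ only in the substituted phenyl group on an aromatic nitrogen. In a functional assay on SGC-7901 cells (Homo sapiens) for inhibition, read by MTT assay, with a stated time of 24 h (on this read-out higher numbers stand for weaker inhibition and lower numbers for stronger inhibition), compound 1 gives 500 nM, compound 2 gives 220 nM and compound 3 gives 410 nM. Compound 3 cannot be separated from either of the other two, as both of its steps stay within the scatter: a 1.2-fold lower number from compound 1 to compound 3 (0.09 log units; within the scatter) and a 1.9-fold higher number from compound 2 to compound 3 (0.27 log units; within the scatter). Among the compounds with values here, the only step beyond the scatter is a 2.3-fold lower number from compound 1 to compound 2 (0.36 log units; beyond the scatter), and it is modest.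

Compound 4 `COc1cccc(-n2cc(CN3C(=O)C[C@@H]4CC[C@@]3(C)C4(C)C)nn2)c1` changes the same group again: 3-methoxyphenyl in place of 2-hydroxyphenyl on an aromatic nitrogen. In words, 3-methoxyphenyl comes in place of 2-hydroxyphenyl. Within the data shown here, no measured compound carries this new group, so the three steps offer only a rough guide. With a 2.3-fold lower number from compound 1 to compound 2 (0.36 log units; beyond the scatter) as the largest of them, no step beyond the scatter is expected in this assay. The expected change is a 1.1-fold lower number from compound 3 to compound 4 (0.03 log units; within the scatter).

For compound 4 the estimated value is 380 nM, with an expected range from 160 nM to 900 nM.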

Compound 4, half-maximal inhibitory concentration: 590 nM
Estimate against measurement, compound 4: 1.6-fold (0.19 log units) below, and the stated range covers the measured number.
By their numbers in this assay, from the lowest: compounds 2, 3, 1 and 4 (each within the scatter of the next, the first and the last beyond it).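

Within the data shown here, replacing 2-hydroxyphenyl with 3-methoxyphenyl, which has no hydrogen-bond donor, gives a 1.4-fold higher number from compound 3 to compound 4 (0.16 log units; within the scatter) in this assay, so removing the donor in this change produces no step that can be told from the scatter. Compound 4 also cannot be separated from the 4-fluorophenyl compound, with a 1.2-fold higher number from compound 1 to compound 4 (0.07 log units; within the scatter), but a 2.7-fold higher number from compound 2 to compound 4 (0.43 log units; beyond the scatter) adds a second step beyond the scatter for 2-chlorophenyl, which now stands apart from both 4-fluorophenyl and 3-methoxyphenyl, though not from 2-hydroxyphenyl. Nothing available explains these differences.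

Compound 3 and compound 4 differ both in the group and in where it sits, so the compounds shown cannot separate those two changes, and a 2-methoxyphenyl group would be needed to do so. Going by these compounds, how a phenyl ring carrying an amine or a carboxylic acid would read in this assay also remains open.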